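Phenyl for methyl on a weak fused-pyrazole core

The source may hold more compounds than are shown below. What is called first, only, known or untested is meant among the compounds shown, and "the series" means these compounds.

Measured compounds:
Compound 1, `COc1ccc(C2C(C#N)=C(N)Oc3c2c(-c2ccccc2)nn3C)cc1F`: > 10000 nM in a functional assay on NCI-H2122 cells (Homo sapiens) for inhibition, read by microscopy, with a stated time of 10 days; a higher number here means a weaker inhibitor, a lower number a stronger inhibitor
Compound 2, `Cc1nn(C)c2c1C(c1cccnc1)C(C#N)=C(N)O2`: 8800 nM

Of the compounds shown here, two have been tested so far. Compound 1 `COc1ccc(C2C(C#N)=C(N)Oc3c2c(-c2ccccc2)nn3C)cc1F` reaches only the limit of this assay, > 10000 nM, which is a boundary of the measurement and not a number. Going by the values given here, compound 2 `Cc1nn(C)c2c1C(c1cccnc1)C(C#N)=C(N)O2` is the one compound with a numerical half-maximal inhibitory concentration in this assay, 8800 nM, so it is the only point of reference, with the limit of > 10000 nM in this assay, at which 1 of the 2 values shown sits, standing beside it.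

Compound 3 `Cn1nc(-c2ccccc2)c2c1OC(N)=C(C#N)C2c1cccnc1` has not yet been measured. It differs from compound 2 in one place: phenyl in place of methyl on an aromatic carbon. Among the compounds with values here, no pair of measured compounds shows the effect of this exact change, so the size of the step from compound 2 to compound 3 cannot be read from the data; compound 1, which carries a phenyl at the same place but a different aryl group elsewhere, sits at the limit. On that slim basis, compound 3 is expected to give roughly 10000 nM in this assay, in a range from 3000 nM to 40000 nM, with a fair chance that only a limit is reported. The expected step of a 1.1-fold higher number from compound 2 to compound 3 (0.06 log units; within the scatter) is, therefore, no more than the usual scatter or a mild weakening.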

Compound 3, half-maximal inhibitory concentration: > 10000 nM
Compound 3 ended at the assay's limit; the forecaster's own chance of this, stated with the estimate: 55%; the middle value sits exactly at the limit.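

In this assay compound 3 gives > 10000 nM, which is a limit of the assay and not a number. Going by these compounds alone, with the pyridin-3-yl group held constant, phenyl in place of methyl on this aromatic carbon is now seen as the only change, giving an at least 1.1-fold higher number from compound 2 to compound 3 (0.05 log units; that floor lies within the scatter); that figure is only a floor, so the true size of the step remains unknown. The step between compound 1 and compound 3 cannot be read, and the two compounds with phenyl at this place share the same limit: the limit of > 10000 nM in this assay, at which 2 of the 3 values shown sit.

In this assay compound 2 gives 8800 nM. Going by these compounds, it remains open whether another group on this aromatic carbon, such as an ethyl chain, an amine or a carboxylic acid, would give a clearly lower number. Also open, on these data alone, is what methyl at this place would give alongside 3-fluoro-4-methoxyphenyl on the saturated ring carbon.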